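Compound 4: 4-hydroxyphenyl in place of 3-hydroxyphenyl

A few compounds are considered here, and "the series" means these few. Any claim that something is new, unique, unknown or untested is made for them only; others in the source may bear on it.

In a functional assay on MCF7 cells (Homo sapiens) for inhibition, read by fluorescence, with a stated time of 72 h (a higher number here means a weaker inhibitor of growth, a lower number a stronger inhibitor of growth), compound 3 `CC(C)CCn1cnc2c(Nc3cccc(O)c3)nc(N[C@H]3CC[C@H](N)CC3)nc21` stands highest of the three numbers at 12600 nM while compound 2 `CC(C)CCn1cnc2c(Nc3ccccc3)nc(N[C@H]3CC[C@H](N)CC3)nc21` gives 5400 nM and compound 1 `CC(C)CCn1cnc2c(Nc3cccc(Cl)c3)nc(N[C@H]3CC[C@H](N)CC3)nc21` gives 2100 nM on the same scale. Compound 4 `CC(C)CCn1cnc2c(Nc3ccc(O)cc3)nc(N[C@H]3CC[C@H](N)CC3)nc21` carries 4-hydroxyphenyl in place of 3-hydroxyphenyl on a nitrogen on an aromatic ring is the whole difference. Among the measured compounds shown here, the nearest evidence is a 2.3-fold higher number from compound 2 to compound 3 (0.37 log units; beyond the scatter) for hydroxy in place of hydrogen and a 6.0-fold higher number from compound 1 to compound 3 (0.78 log units; beyond the scatter) for hydroxy in place of chloro and both are modest, yet no measured step moves a group around the ring. In this assay no step beyond the scatter is therefore expected, and the direction is only weakly held. The estimated change is a 1.4-fold lower number from compound 3 to compound 4 (0.15 log units; within the scatter) in this series. Compound 4 is expected at 9000 nM with an estimated range of 3500 nM to 22000 nM in this assay.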

Compound 4, concentration for 50% growth inhibition: 3100 nM
The estimate for compound 4 lay 2.9-fold (0.46 log units) above the measured number, outside the stated range (below it).
By their numbers in this assay, from the lowest: compounds 1, 4 and 2 (each within the scatter of the next, the first and the last beyond it); then compound 3.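

In this assay, moving the hydroxy around the ring is a step of its own, beyond the scatter (a 4.1-fold lower number from compound 3 to compound 4 (0.61 log units; beyond the scatter)), so 3-hydroxyphenyl and 4-hydroxyphenyl on a nitrogen on an aromatic ring do not read alike. The earlier cost of hydroxy does not carry over to 4-hydroxyphenyl, which stays within the scatter of the unsubstituted phenyl (a 1.7-fold lower number from compound 2 to compound 4 (0.24 log units; within the scatter)) and of 3-chlorophenyl (a 1.5-fold higher number from compound 1 to compound 4 (0.17 log units; within the scatter)). From the compounds shown here alone, whether 4-methoxyphenyl or 4-aminophenyl on that nitrogen would read like 4-hydroxyphenyl remains open. Nothing at hand explains the difference between the two hydroxyphenyl compounds.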